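A few compounds are considered here, and "the series" means these few. Any claim that something is new, unique, unknown or untested is made for them only; others in the source may bear on it.

Measured so far:
Compound 1, `CC(=O)OC[C@H]1O[C@@H](CC(=O)/C=C/c2cccnc2)[C@H](OC(C)=O)[C@@H](OC(C)=O)[C@@H]1OC(C)=O` — 4.17 nM in an ADME assay on cells (Epithelial cell, Homo sapiens) for cytotoxicity, read by MTT assay, with a stated time of 24 h; on this read-out higher numbers stand for lower toxicity in this test and lower numbers for higher toxicity in this test
Compound 2, `COc1cc(/C=C/C(=O)C[C@@H]2O[C@H](COC(C)=O)[C@@H](OC(C)=O)[C@H](OC(C)=O)[C@H]2OC(C)=O)cc(OC)c1OC` — "not determined" (no result reported) in this assay
Compound 3, `CC(=O)OC[C@H]1O[C@@H](CC(=O)/C=C/c2ccc(OCc3ccccc3)cc2)[C@H](OC(C)=O)[C@@H](OC(C)=O)[C@@H]1OC(C)=O` — "not determined" (no result reported) in this assay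

Compound 2 stands without a single number in this assay; compound 3 is the other entry without one, so only compound 1 carries a value in this series. Compound 1 gives 4.17 nM in this assay, and that number is the sole point of reference for anything that follows.

Compound 4, `CC(=O)OC[C@H]1O[C@@H](CC(=O)/C=C/c2ccc(C)cc2)[C@H](OC(C)=O)[C@@H](OC(C)=O)[C@@H]1OC(C)=O`, is not yet measured. It differs from compound 2 in one place: 4-methylphenyl in place of 3,4,5-trimethoxyphenyl on a double-bonded chain carbon bound to a double-bonded chain carbon. Since no number exists for compound 2, no direction can be read from the pair itself; any shift from compound 2 to compound 4 in this assay can neither be placed within nor beyond the scatter on what is shown. The shared core and the enone linker of compound 1 are retained, and the change is confined to the aryl group on the double-bonded chain carbon.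

Going by the values given here, on that basis compound 4 is expected to give about 5 nM in this assay, with a range from 1.5 nM to 20 nM, the spread kept wide because the only anchor is compound 1 at 4.17 nM.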

Compound 4, half-maximal cytotoxic concentration: 3.18 nM
Beside the measured number, compound 4's estimate is 1.6-fold (0.20 log units) above it, and the stated range covers the measured number.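

Working notes: at the place on a double-bonded chain carbon bound to a double-bonded chain carbon, two aryl groups can now be compared in this assay, and 4-methylphenyl in place of pyridin-3-yl gives a 1.3-fold lower number from compound 1 to compound 4 (0.12 log units; within the scatter) on the shared core with its enone linker. Going by these compounds alone, on this one pair, the two groups cannot be told apart in this read-out, so exchanging the pyridin-3-yl ring for a ring of carbon only that carries a methyl group gives no readable difference. No measurement is available that bears on the reason for this result.

Compound 2 and compound 3 carry no number in this assay, so every step to either of them cannot be read, and the series gives no information on 3,4,5-trimethoxyphenyl or on the benzyloxy-bearing aryl group at this place. Also open, as far as these compounds go, is whether a different group on the aryl ring, such as an amine, a carboxylic acid or a longer alkyl chain in place of the methyl of 4-methylphenyl, would give a step beyond the scatter.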